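Methyl in Place of Bromo: an Expected Antiproliferative Value

A few compounds are considered here, and "the series" means these few. Any claim that something is new, unique, unknown or untested is made for them only; others in the source may bear on it.

Measured compounds:
compound 1 `COc1ccc(/C=C2\S/C(=N\c3ccc(Cl)cc3)N(C)C2=O)cc1` — 39300 nM
compound 2 `COc1ccc(/C=C2\S/C(=N\c3ccc(C)c(Cl)c3)N(C)C2=O)cc1` — > 100000 nM
compound 3 `COc1ccc(/C=C2\S/C(=N\c3ccc(Br)cc3)N(C)C2=O)cc1` — > 100000 nM

Of the compounds shown here, three sharing one core have been tested in a functional assay on MCF7 cells (Homo sapiens) for antiproliferative activity, read by MTT assay, with a stated time of 72 h; a higher number here means a weaker inhibitor, a lower number a stronger inhibitor. Compound 1 gives 39300 nM. Compound 2 reaches only a limit of the assay, > 100000 nM. Compound 3 likewise reaches only a limit, > 100000 nM, so for compound 3 no number is known, and it sits at the limit of > 100000 nM in this assay, at which 2 of the 3 values shown sit. The step of an at least 2.5-fold higher number from compound 1 to compound 3 (0.40 log units; beyond the scatter) is readable only as a lower bound, as is an at least 2.5-fold higher number from compound 1 to compound 2 (0.40 log units; beyond the scatter); the step that the two limits leave unreadable from compound 2 to compound 3 cannot be read at all.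

Compound 4 `COc1ccc(/C=C2\S/C(=N\c3ccc(C)cc3)N(C)C2=O)cc1` is not yet measured. It differs from compound 3 by methyl in place of bromo on an aromatic carbon. Among the measured compounds shown here, the steps that bear on this are the two bounded ones: both changes away from compound 1, the chloro to bromo exchange and the change to 3-chloro-4-methylphenyl, carried the value to the limit. For the measured compounds named here, no measured step isolates methyl against bromo on this ring, so the direction of an at least 1.2-fold lower number from compound 3 to compound 4 (0.09 log units; that floor lies within the scatter) is expected to be uncertain and probably small relative to the limit. Compound 4 is therefore estimated at 80000 nM in this assay. Its expected range for compound 4 runs from 30000 nM to 200000 nM, with a substantial chance that the assay again reports only a limit.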

Compound 4, half-maximal inhibitory concentration: > 100000 nM
Compound 4 was reported as a limit (the forecaster's own chance of this, stated with the estimate: 45%); middle value at least 1.2-fold (0.09 log units) from the limit.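

In this assay, compound 4 gives a limit and not a number, so methyl joins bromo at this position on the ring, and the earlier loss of a readable value is no longer confined to compound 3 and compound 2: the limit of > 100000 nM in this assay, at which 3 of the 4 values shown sit. Swapping the chloro group for methyl gives an at least 2.5-fold higher number from compound 1 to compound 4 (0.40 log units; beyond the scatter), which makes compound 1, with its chloro group, the only one of the four compounds that gives a measured number in this series, and that number is 39300 nM. The steps to compound 4 from compound 2 and from compound 3 join two limits and cannot be read, so methyl and bromo cannot be placed in any order.

Going by these compounds, how far compound 2, compound 3 and compound 4 lie beyond the limit remains open, and so does whether the chloro group of compound 1 marks a real preference at this position. Also open, on these data alone, is whether a quite different group there, such as an amine or a carboxylic acid, would give a lower number than compound 1 does.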